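This account rests on a few compounds, and the source may have more. Where it says the series, first, only, none or still open, it means among the compounds named here.

Measured compounds:
compound 1 `COc1cc(Cn2cc(CNC(=O)c3cn(-c4ccccc4)nc3-c3ccc(F)cc3)nn2)cc(OC)c1OC`: 4300 nM
compound 2 `COc1ccc(Cn2cc(CNC(=O)c3cn(-c4ccccc4)nc3-c3ccc(OC)cc3)nn2)cc1`: 22900 nM
compound 3 `COc1ccc(-c2nn(-c3ccccc3)cc2C(=O)NCc2cn(Cc3cc(OC)cc(OC)c3)nn2)cc1`: 700 nM

In a functional assay on MCF7 cells (Homo sapiens) for antiproliferative activity, read by sulforhodamine B assay, with a stated time of 48 h (on this read-out higher numbers stand for weaker inhibition of growth and lower numbers for stronger inhibition of growth), these three compounds share one core and differ in the two aryl groups hung on it. Compound 3 gives the lowest number of the three; compound 1 sits a clear distance above it, and compound 2 further still. Among the measured compounds shown here, the one single-point step among them, a 33-fold lower number from compound 2 to compound 3 (1.51 log units; beyond the scatter), shows how much the group on the saturated chain carbon bound to an aromatic nitrogen can matter.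

Compound 4 `COc1ccc(-c2nn(-c3ccccc3)cc2C(=O)NCc2cn(Cc3cc(OC)c(OC)c(OC)c3)nn2)cc1` is the next single-point change from compound 3: methoxy in place of hydrogen on an aromatic carbon. For the measured compounds named here, no measured step covers exactly this change. Compound 1 does carry the 3,4,5-trimethoxyphenyl group, but it also differs from compound 4 in the other aryl group, so its value and that of compound 4 cannot be set side by side as a clean step. Going by the values given here, the only guidance is that the benzyl group shifts the read-out strongly in the one step seen, and that compound 1, the sole trimethoxy example, does not give a low number. The step of a 2.1-fold higher number from compound 3 to compound 4 (0.33 log units; beyond the scatter) is therefore expected to run modestly upward, with wide uncertainty. Compound 4 is estimated at 1500 nM, within 400 nM to 6000 nM.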

Compound 4, concentration for 50% growth inhibition: 7600 nM
The estimate for compound 4 lay 5.1-fold (0.70 log units) below the measured number; the whole stated range lies below it.
By their numbers in this assay, from the lowest: compound 3; then compounds 1 and 4 (each within the scatter of the next); then compound 2.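

In this assay the added methoxy, on the ring carbon ortho to two methoxy groups and para to a large group, is no small edit: the change gives an 11-fold higher number from compound 3 to compound 4 (1.04 log units; beyond the scatter) and removes most of the advantage that the 3,5-dimethoxyphenyl group showed over the 4-methoxyphenyl group. The 3,4,5-trimethoxyphenyl group still improves on 4-methoxyphenyl, with a 3.0-fold lower number from compound 2 to compound 4 (0.48 log units; beyond the scatter) against the larger 33-fold lower number from compound 2 to compound 3 (1.51 log units; beyond the scatter) for 3,5-dimethoxyphenyl, so among these three compounds the pattern of methoxy groups matters and adding more does not steadily lower the number. On the other aryl group, a 1.8-fold higher number from compound 1 to compound 4 (0.25 log units; within the scatter) shows that methoxy and fluoro cannot be told apart in this assay when the 3,4,5-trimethoxyphenyl group is present.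

No measurement offered here accounts for the effect of the added methoxy. Still open, going by these compounds, is whether a hydroxyl, a chlorine atom or an amine at that same ring position would preserve the low number of compound 3, and whether fluoro and methoxy would also match when paired with the 3,5-dimethoxyphenyl group.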